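Swapping the Distal Aryl Group in a Biphenyl Amide Series

This account rests on a few compounds, and the source may have more. Where it says the series, first, only, none or still open, it means among the compounds named here.

Compound 1 `Cc1ccc(-c2ccc(N(C[C@@H](N)CC(C)C)C(=O)[C@@H]3C[C@H]3c3ccccc3)cc2)cc1`: 360 nM
Compound 2 `CC(C)C[C@H](N)CN(C(=O)[C@@H]1C[C@H]1c1ccccc1)c1ccc(-c2ccc(C#N)cc2)cc1`: 670 nM

In a functional assay for agonist activity at G protein-coupled receptor 88 (Homo sapiens), read by HTRF and cAMP accumulation (a lower number here means that less compound is needed, a higher number that more compound is needed for the effect), compound 2 gives 670 nM. Within the data shown here, its only neighbour is compound 1, and the two cannot be separated: a 1.9-fold higher number from compound 1 to compound 2 (0.27 log units; within the scatter). Compound 3 `CC(C)C[C@H](N)CN(C(=O)[C@@H]1C[C@H]1c1ccccc1)c1ccc(-c2ccccc2Cl)cc1` carries 2-chlorophenyl in place of 4-cyanophenyl on an aromatic carbon. Among the measured compounds shown here, the single measured step, the change from compound 1 to compound 2 at the same aromatic carbon, stayed within the scatter, and no measured step addresses a 2-chlorophenyl group. The expected step is therefore a 1.2-fold higher number from compound 2 to compound 3 (0.08 log units; within the scatter), nothing beyond the scatter. Compound 3 is estimated at 800 nM, within a range from 300 nM to 2500 nM.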

Compound 3, half-maximal effective concentration: 3800 nM
Compound 3: the middle estimate sits 4.8-fold (0.68 log units) below what was measured; the whole stated range lies below it.
By their numbers in this assay, from the lowest: compounds 1 and 2 (each within the scatter of the next); then compound 3.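

At this aromatic carbon, the earlier change from 4-methylphenyl to 4-cyanophenyl stayed within the scatter in this assay, but 2-chlorophenyl moves the number well beyond it, with (a 5.7-fold higher number from compound 2 to compound 3 (0.75 log units; beyond the scatter)) and (an 11-fold higher number from compound 1 to compound 3 (1.02 log units; beyond the scatter)). The position is therefore not indifferent to the aryl group it carries. Nothing available explains this rise. The compounds shown leave open whether the rise follows the chlorine itself or its place on the ring. A 4-chlorophenyl or an unsubstituted phenyl group would help separate the two.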